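Methoxy for Bromo, Tried on a Second Core

The compounds below may be only part of what the source reports. "The series", "measured", "known", "first", "only" and "open" are said of these compounds alone.

Measured compounds in a functional assay on WiDr cells (Homo sapiens) for inhibition, read by sulforhodamine B assay, with a stated time of 48 h; a higher number here means a weaker inhibitor of growth, a lower number a stronger inhibitor of growth:
Compound 1 `COC(=O)[C@@]1(C)CC[C@@H]2C3=C1CC[C@@H](C)[C@]3(C)C[C@@H]1c3cc(Br)ccc3N[C@H]21` gives 55000 nM.
Compound 2 `COC(=O)[C@@]1(C)CC[C@@H]2C3=C1CC[C@@H](C)[C@]3(C)C[C@@H]1c3cc(OC)ccc3N[C@H]21` gives 25000 nM.
Compound 3 `COC(=O)[C@@]1(C)CC[C@@H]2C3=C1CC[C@@H](C)[C@]3(C)Cc1c2[nH]c2ccc(Br)cc12` gives 22000 nM.

Compound 1 and compound 2 share one core and differ by a single change, (methoxy in place of bromo on an aromatic carbon). In this assay that change gave a 2.2-fold lower number from compound 1 to compound 2 (0.34 log units; beyond the scatter), a modest step, though it lies beyond the scatter of repeated measurements.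

Compound 3 is built on another core; the difference between the two cores is not broken down here. Its value and that of compound 2 lie within the scatter of each other, so nothing can be said about their order. Compound 4 `COC(=O)[C@@]1(C)CC[C@@H]2C3=C1CC[C@@H](C)[C@]3(C)Cc1c2[nH]c2ccc(OC)cc12` is compound 3 carrying the same change, (methoxy in place of bromo on an aromatic carbon); the surroundings of the place are described in the same words for both pairs, so this is the same change on a different core.

The expectation for compound 4 rests on the step from compound 1 to compound 2: the same change is expected to give a similar step, a 2.2-fold lower number from compound 3 to compound 4 (0.34 log units; beyond the scatter), in this assay, because a 2.2-fold lower number from compound 1 to compound 2 (0.34 log units; beyond the scatter) was seen on the first core. Compound 4 is therefore estimated at 10000 nM in this assay, with a likely range from 5000 nM to 22000 nM.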

Compound 4, concentration for 50% growth inhibition: 1200 nM
Estimate against measurement, compound 4: 8.3-fold (0.92 log units) above; measured number below the stated range.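

In this assay, putting methoxy in place of bromo gave an 18-fold lower number from compound 3 to compound 4 (1.26 log units; beyond the scatter), so on both cores the number fell, but the size of the step did not carry over from one core to the other: the same change on two cores in this assay, a 2.2-fold lower number (0.34 log units; beyond the scatter) from compound 1 to compound 2 and an 18-fold lower number (1.26 log units; beyond the scatter) from compound 3 to compound 4, 8.3-fold (0.92 log units) apart, beyond the scatter of two such steps

For this series, the direction of the change held in both pairs, while the step seen on the core of compound 1 proved a poor guide to the size of the step on the core of compound 3. Among the compounds shown here, with only two pairs, this does not show why the steps differ, which part of the difference between the cores matters, or whether the same would hold on a third core.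

Only bromo and methoxy are shown at this place, so it remains open how a hydroxyl group, an amine or a longer chain such as ethoxy would behave on either core. As far as these compounds go, it also remains open whether the larger step on the core of compound 3 extends to any group other than methoxy.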